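Compound 2 to compound 4: phenyl for 5-bromopentyl

This account rests on a few compounds, and the source may have more. Where it says the series, first, only, none or still open, it means among the compounds named here.

In a functional assay on HL-60 cells (Homo sapiens) for cytotoxicity, read by MTT assay, with a stated time of 24 h (on this read-out lower numbers stand for stronger inhibition and higher numbers for weaker inhibition), compound 1 `CC(C)(C)OC(=O)N1CCCN(CCCCCOc2c(Br)cc(Br)cc2Oc2ccc(Br)cc2Br)CC1` gives 44.8 ug/mL and compound 3 `Cc1ccc(S(=O)(=O)n2nc(N3CCN(CCCCCOc4c(Br)cc(Br)cc4Oc4ccc(Br)cc4Br)CC3)c3cc([N+](=O)[O-])ccc32)cc1` gives 52.5 ug/mL while compound 2 `BrCCCCCCOc1c(Br)cc(Br)cc1Oc1ccc(Br)cc1Br` gives 37.8 ug/mL and stands within the scatter of both.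

Compound 4 `Brc1ccc(Oc2cc(Br)cc(Br)c2OCc2ccccc2)c(Br)c1` is not yet measured. It carries phenyl in place of 5-bromopentyl on a saturated chain carbon bound to an oxygen on an aromatic ring, counted as phenyl in place of 5-bromopentyl on a saturated chain carbon bound to an oxygen on an aromatic ring against compound 2.

Among the measured compounds shown here, no measured pair isolates this change. Compound 1 at 44.8 ug/mL and compound 3 at 52.5 ug/mL sit within the scatter of compound 2 despite their different chain ends, so no step beyond the scatter is expected in this assay here. The estimated 1.1-fold higher number from compound 2 to compound 4 (0.02 log units; within the scatter) is small. Compound 4 is estimated at 40 ug/mL with 20 ug/mL to 75 ug/mL as its expected range.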

Compound 4, half-maximal inhibitory concentration: 27.9 ug/mL
Compound 4: middle estimate off by 1.4-fold (0.16 log units), on the high side; the measured number falls inside the stated range.
By their numbers in this assay, from the lowest: compounds 4, 2, 1 and 3 (each within the scatter of the next).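

In this assay, phenyl in place of 5-bromopentyl on a saturated chain carbon bound to an oxygen on an aromatic ring gives a 1.4-fold lower number from compound 2 to compound 4 (0.13 log units; within the scatter). This position therefore takes a six-membered aromatic ring of carbon only in place of a bromine-ended chain, with no step beyond the scatter. Nothing measured alongside these numbers bears on this result. From the compounds shown here alone, whether a carboxylic acid or a primary amine at this place would give a step beyond the scatter stays open, as does whether this read-out responds to this position at all.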